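Swapping the nitrile-bearing ring for a methyl oxadiazole

The compounds below may be only part of what the source reports. "The series", "measured", "known", "first", "only" and "open" are said of these compounds alone.

Measured in an ADME assay on cells (Hepatocyte, Homo sapiens) for metabolic stability; a lower number here means that the compound disappears faster, a higher number that the compound lasts longer:
- Compound 1 `N#Cc1ccc(N2CCC(C(=O)N3N=CC[C@H]3c3cc(F)cc(F)c3)CC2)nn1`: > 8 h (a limit of the assay, not a number)
- Compound 2 `Cc1nnc(N2CCC(C(=O)N3N=CC[C@H]3c3ccccc3)CC2)o1`: 3.3 h
- Compound 3 `N#Cc1cnc(N2CCC(C(=O)N3N=CC[C@H]3c3cc(F)cc(F)c3)CC2)cn1`: 3.3 h

Compound 3 stands level with compound 2 at the digits shown, and the two readings lie within the scatter of each other. Compound 1 reports only a limit, so its reading is not a number.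

The next compound is compound 4 `Cc1nnc(N2CCC(C(=O)N3N=CC[C@H]3c3cc(F)cc(F)c3)CC2)o1`, and the change is 5-methyl-1,3,4-oxadiazol-2-yl in place of 5-cyanopyrazin-2-yl on an amine nitrogen in a ring. In words, a 5-methyl-1,3,4-oxadiazol-2-yl group takes the place of the 5-cyanopyrazin-2-yl group on an amine nitrogen in a ring.

For the measured compounds named here, only one measured step touches this place, and it is an at least 2.4-fold lower number from compound 1 to compound 3 (0.38 log units; beyond the scatter). That step shows that this assay can respond to a swap of this group, but it exchanges one six-membered aromatic ring for another and so gives no direction for the present change. Differing from compound 4 elsewhere but carrying the same 5-methyl-1,3,4-oxadiazol-2-yl group, compound 2 gives 3.3 h as the closest guide. No step beyond the scatter is therefore expected.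

The expected change is a 1.4-fold higher number from compound 3 to compound 4 (0.13 log units; within the scatter).

For compound 4 the estimated half-life is 4.5 h, with an expected range from 2.2 h to 9 h.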

Compound 4, half-life: 3.3 h
Compound 4: the middle estimate sits 1.4-fold (0.13 log units) above what was measured, within the range that was stated.
By their numbers in this assay, from the lowest: compounds 2, 3 and 4 (each within the scatter of the next). At a limit, above all of these: compound 1.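

In this assay, the 5-methyl-1,3,4-oxadiazol-2-yl and 5-cyanopyrazin-2-yl groups on this amine nitrogen cannot be told apart on the shared core, with no change at the digits printed from compound 3 to compound 4 (within the scatter). With the oxadiazole in place, 3,5-difluorophenyl and phenyl on the saturated ring carbon cannot be told apart either, with no change at the digits printed from compound 2 to compound 4 (within the scatter). The nitrile-bearing ring of compound 1 remains the only group at this position that separates from the others, with an at least 2.4-fold lower number from compound 1 to compound 4 (0.38 log units; beyond the scatter), a step that rests on a limit and not on a number: the limit of > 8 h in this assay, at which 1 of the 4 values shown sits.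

The compounds shown leave open how far compound 1 really lies from the others, and whether the two fluorines would count any differently with a nitrile-bearing ring on the amine nitrogen. They also give no guide to how a non-aromatic group on that nitrogen, such as an acetyl or a methyl carbamate, or chlorine in place of the fluorines, would read in this assay.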